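The compounds below may be only part of what the source reports. "The series", "measured", "known", "first", "only" and "open" are said of these compounds alone.

Compound 1 `COc1ccc(-c2cc3cccc(OC)c3nc2O)cc1`: 10000 nM
Compound 2 `CCN(CC)C(=O)Cn1c(=O)c(-c2ccc(OC)cc2)cc2c(OC)cc(OC)cc21`: 10000 nM

In a functional assay on J82 cells (Homo sapiens) for cytotoxicity, read by colorimetric assay and MTT assay (a lower number here means a stronger inhibitor, a higher number a weaker inhibitor), compound 1 gives 10000 nM and compound 2 gives 10000 nM, so compound 2 stands level with compound 1 at the digits available. Neither compound is separated from the other in this assay, even though their structures differ in more than one place.

Compound 3 `COc1ccc(-c2cc3c(OC)cc(OC)cc3n(CCC#N)c2=O)cc1` has not yet been measured. It keeps the core of compound 2 and changes a single group: cyanomethyl in place of diethylcarbamoyl on a saturated chain carbon bound to an aromatic nitrogen. Cut one bond further out, the same difference reads (diethylcarbamoyl)methyl to 2-cyanoethyl.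

Going by the values given here, no measured pair shows this change, so its size cannot be read directly from the data. Among the compounds with values here, the only guide is that compound 2, at 10000 nM, sits level with compound 1, and so no step beyond the scatter is expected in either direction. The expected change is a 1.3-fold lower number from compound 2 to compound 3 (0.10 log units; within the scatter). For compound 3 the estimated value is 8000 nM, with an expected range from 2500 nM to 20000 nM.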

Compound 3, half-maximal inhibitory concentration: 10000 nM
Compound 3: middle estimate off by 1.3-fold (0.10 log units), on the low side; low and high end bracket the measured number.
By their numbers in this assay, from the lowest: compounds 1, 2 and 3 (each within the scatter of the next).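

In this assay, putting cyanomethyl in place of diethylcarbamoyl on a saturated chain carbon bound to an aromatic nitrogen gives no change at the digits printed from compound 2 to compound 3 (within the scatter). Going by these compounds alone, this is the first reading of a single change at this position, which compounds 1 and 2, differing in more than one place, could not supply, and it shows that a nitrile can replace the amide carbonyl and its diethylamino end here without separating the two compounds in this cell assay. No measurement on hand bears on why the reading stays level, so the result stands as an observation only.

As far as these compounds go, what remains open is whether any group at this place can separate itself from compound 2 at all, since the two groups compared here give one and the same reading and show no direction of change. A primary amine, a carboxylic acid or a longer chain ending in a nitrile on the same saturated carbon would test this, and the compounds shown say nothing about how such groups would read.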